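Methyl added to the benzyl group of compound 3

A few compounds are considered here, and "the series" means these few. Any claim that something is new, unique, unknown or untested is made for them only; others in the source may bear on it.

Measured so far in a functional assay on MCF7 cells (Homo sapiens) for cytotoxicity, read by MTT assay, with a stated time of 24 h, tested at 1.6 ug/mL; a lower number here means a weaker effect, a higher number a stronger effect of the compound at the concentration tested:
compound 1 `CN1CCN(CC(=O)Nc2ccc(-c3nc(-c4ccccc4)c(-c4ccccc4)n3C)cc2)CC1` gives 2.9%
compound 2 `CN(C)/C=C/N1CCN(CC(=O)Nc2ccc(-c3nc(-c4ccccc4)c(-c4ccccc4)n3C)cc2)CC1` gives 1.9%
compound 3 `Cn1c(-c2ccc(NC(=O)CN3CCN(Cc4ccccc4)CC3)cc2)nc(-c2ccccc2)c1-c1ccccc1` gives 13.3%

Compound 3 stands highest of the three numbers; its nearest neighbour is compound 1, the step of a number 10.4 percentage points higher from compound 1 to compound 3 (beyond the scatter), and its furthest is compound 2, the step of a number 11.4 percentage points higher from compound 2 to compound 3 (beyond the scatter). Both of those steps are beyond the scatter, so compound 3 counts as the most active of the set on this read-out. The step of a number 1 percentage points lower from compound 1 to compound 2 (within the scatter) is within the scatter.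

Compound 4 `Cc1ccc(CN2CCN(CC(=O)Nc3ccc(-c4nc(-c5ccccc5)c(-c5ccccc5)n4C)cc3)CC2)cc1` differs from compound 3 by methyl in place of hydrogen on an aromatic carbon. Among the compounds with values here, no measured step touches an aromatic carbon; the two informative steps, from compound 1 and from compound 2 to compound 3, concern the amine nitrogen in the ring and were each of modest size. They say nothing direct about a methyl on the benzyl group. Within the data shown here, with no bearing step, the expectation for compound 4 is a step of a number 0.7 percentage points higher from compound 3 to compound 4 (within the scatter), i.e. none beyond the scatter. Compound 4 is therefore estimated at 14%, with a range from 4% to 26%.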

Compound 4, a percentage reported as activity, at one concentration (the size of the read-out at that concentration, not a potency): 19.3%
The estimate for compound 4 lay 5.3 percentage points below the measured number; low and high end bracket the measured number.
By their numbers in this assay, from the lowest: compounds 2 and 1 (each within the scatter of the next); then compounds 3 and 4 (each within the scatter of the next).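

In this assay the first substitution shown on the aromatic ring of the benzyl group gives a number 6 percentage points higher from compound 3 to compound 4 (within the scatter), so methyl on this aromatic carbon, para to a large group, leaves 4-methylbenzyl not distinguishable from benzyl on this read-out. The separation from the two compounds without a benzyl-type group survives the added methyl, with a number 17.4 percentage points higher from compound 2 to compound 4 (beyond the scatter) and a number 16.4 percentage points higher from compound 1 to compound 4 (beyond the scatter), both modest, so the gain seen with benzyl on the amine nitrogen in the ring also holds for 4-methylbenzyl. Nothing at hand explains these steps.

On these data alone, whether this aromatic carbon responds to anything at all remains open: a larger or different group there, such as a methoxy, a chlorine, a carboxylic acid or a longer chain, could show whether the position can move the read-out beyond the scatter, and the same groups at the other carbons of that ring would show whether the place matters. As far as these compounds go, each number in this assay is the size of the effect at one concentration, so how the effects of compound 3 and compound 4 compare at other concentrations also stays open.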